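Shortening the Carbamate Chain of a Selenocyanate

The compounds below may be only part of what the source reports. "The series", "measured", "known", "first", "only" and "open" are said of these compounds alone.

Among the measured compounds shown here, compound 1 `CCCOC(=O)Nc1ccc([Se]C#N)cc1` gives the lower of the two numbers measured so far in an ADME assay on BEAS-2B cells (Homo sapiens) for cytotoxicity, read by MTT assay, with a stated time of 72 h (a lower number here means a stronger inhibitor of growth, a higher number a weaker inhibitor of growth), namely 19200 nM. Compound 2 `CCCCOC(=O)Nc1ccc([Se][Se]c2ccc(NC(=O)OCCCC)cc2)cc1` gives 24200 nM in this assay, a number within the scatter of that of compound 1. Compound 3 `CCOC(=O)Nc1ccc([Se]C#N)cc1` differs from compound 1 by hydrogen in place of methyl on a saturated chain carbon, two bonds along the chain from an oxygen next to a carbonyl group. For the measured compounds named here, no measured pair shows the effect of this change, and the two measured compounds give no ground for a large step. The step of a 1.0-fold higher number from compound 1 to compound 3 (0.02 log units; within the scatter) is therefore expected to stay within the scatter. Compound 3 is estimated at 20000 nM, in the range 8000 nM to 50000 nM.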

Compound 3, concentration for 50% growth inhibition: 21700 nM
Compound 3: the middle estimate sits 1.1-fold (0.04 log units) below what was measured; measured number inside the range.
By their numbers in this assay, from the lowest: compounds 1, 3 and 2 (each within the scatter of the next).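

Among the compounds shown here, the propoxy to ethoxy change gives the first measured step at this position, and in this assay it reads a 1.1-fold higher number from compound 1 to compound 3 (0.05 log units; within the scatter) for hydrogen in place of methyl. The two compounds therefore cannot be told apart in this assay, so at this pair the chain can lose that methyl without a measurable difference. Nothing available here gives a reason for this result. As far as these compounds go, whether a longer chain, an amine or a carboxylic acid in place of the propoxy group would also stay within the scatter remains open.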